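The source may report more compounds than this note shows. Statements on the series, on what has been measured and on what is new or still open speak of the compounds shown alone.

Compound 1 `COc1cccc(-c2nc3c(=O)[nH]c(C)nc3s2)c1` and compound 2 `Cc1nc2sc(-c3cccc(Cl)c3)nc2c(=O)[nH]1` share one core and differ only at one aromatic carbon. In an assay on CHO cells for displacement of a labelled ligand from adenosine receptor A1 (Homo sapiens), read by scintillation counting, with a stated time of 120 min, tested at 1 uM (a lower number here means less inhibition, a higher number more inhibition at the concentration tested (going by the name of the read-out)), compound 1 gives 1%, while compound 2 gives 24%. Going by the values given here, the single measured step is a number 23 percentage points higher from compound 1 to compound 2 (beyond the scatter), and on these two numbers compound 2 stands highest. Compound 3 `Cc1nc2sc(-c3cccc(C(F)(F)F)c3)nc2c(=O)[nH]1` carries trifluoromethyl in place of chloro on an aromatic carbon. Among the compounds with values here, no measured step covers this particular exchange, so the earlier step is only a loose guide, and a change in either direction of modest size at most is expected. Compound 3 is estimated at 25%, between 5% and 50%. That estimate would mean an expected step of a number 1 percentage points higher from compound 2 to compound 3 (within the scatter).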

Compound 3, a percentage reported as inhibition, at one concentration (the size of the read-out at that concentration, not a potency): 1%
Compound 3: the middle estimate sits 24 percentage points above what was measured; the whole stated range lies above it.
By their numbers in this assay, from the lowest: compounds 1 and 3 (each within the scatter of the next); then compound 2.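

In this assay this aromatic carbon proves selective about its group: trifluoromethyl in place of chloro gives a number 23 percentage points lower from compound 2 to compound 3 (beyond the scatter), so the larger group does not keep the reading that chloro gave. Trifluoromethyl in place of methoxy gives no change at the digits printed from compound 1 to compound 3 (within the scatter), which leaves chloro alone among the three groups in standing clear of the others. Nothing available explains this difference between the groups.

On these data alone, how bromo, methyl or an amine at this carbon would read remains open, as does whether any of them would exceed chloro. As far as these compounds go, what a change elsewhere on the shared core would do is also open.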